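Swapping a Carbamate for a Trifluoroacetamide on the Side Chain

This account rests on a few compounds, and the source may have more. Where it says the series, first, only, none or still open, it means among the compounds named here.

Of the compounds shown here, two sharing one core have been measured in an assay on MCF7 cells for inhibition of Serine-protein kinase ATM (Homo sapiens), read by immunofluorescence, with a stated time of 1 h; a lower number here means a stronger inhibitor, a higher number a weaker inhibitor. Compound 1 `COc1cc2ncnc(-n3nc(-c4ccccn4)nc3N)c2cc1[N+](=O)[O-]` carries a nitro group and in this assay compound 1 gives 31100 nM. Compound 2 `COc1cc2ncnc(-n3nc(-c4ccccn4)nc3N)c2cc1OCCCNC(=O)OCC(C)(C)C` instead bears a three-carbon chain ending in a carbamate, and in this assay compound 2 gives 1900 nM. Of the two numbers compound 2 has the lower one, and its gap to compound 1 lies beyond the scatter of repeated measurements.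

Compound 3 `COc1cc2ncnc(-n3nc(-c4ccccn4)nc3N)c2cc1OCCCNC(=O)C(F)(F)F` has not yet been measured. It differs from compound 2 in one place: trifluoromethyl in place of neopentyloxy on a carbonyl carbon. The amide-type nitrogen and the chain that carries it are kept. Within the data shown here, no measured pair in this set shows what such a change at a carbonyl carbon does, so the direction is open and only the value of compound 2, 1900 nM, serves as anchor. A step no larger than the scatter, or at most a modest weakening, is expected. Compound 3 is estimated at 3000 nM, between 800 nM and 12000 nM. The expected 1.6-fold higher number from compound 2 to compound 3 (0.20 log units; within the scatter) is therefore small.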

Compound 3, half-maximal inhibitory concentration in the Serine-protein kinase ATM assay: 2900 nM
Estimate against measurement, compound 3: 1.0-fold (0.01 log units) above, within the range that was stated.
By their numbers in the Serine-protein kinase ATM assay, from the lowest: compounds 2 and 3 (each within the scatter of the next); then compound 1.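

In the Serine-protein kinase ATM assay, the carbonyl carbon of the side chain accepts trifluoromethyl in place of neopentyloxy with a 1.5-fold higher number from compound 2 to compound 3 (0.18 log units; within the scatter), so this exchange of end groups, unlike the earlier exchange at the aromatic carbon, leaves the two compounds within the scatter of each other. The the Serine-protein kinase ATM assay gain over the nitro compound also survives with the new end group, as replacing nitro with the 3-(((trifluoromethyl)carbonyl)amino)propoxy chain gives an 11-fold lower number from compound 1 to compound 3 (1.03 log units; beyond the scatter). The same change at the carbonyl carbon does separate the compounds in a physicochemical assay for solubility, in phosphate buffer, with a stated time of 18 h, at pH 7.4 (a lower number here means a less soluble compound, a higher number a more soluble compound), where compound 2 gives 200 nM and compound 3 gives 1000 nM, so that compound 3 stands clear of compound 2: the measured solubility of compound 2, 200 nM, and of compound 3, 1000 nM, a 5.0-fold higher number (0.70 log units; beyond the scatter)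

The compounds shown leave open whether the difference in the physicochemical assay follows from the trifluoromethyl group itself or from the loss of the neopentyloxy group, a question that a plain methyl or a tert-butyl on the same carbonyl carbon would address. They also leave open how the Serine-protein kinase ATM assay would respond to an amine or a carboxylic acid at the end of the side chain, or to a longer chain carrying the same amide.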